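Replacing Cycloheptyl by Isopropyl on the Ring Nitrogen

The source may hold more compounds than are shown below. What is called first, only, known or untested is meant among the compounds shown, and "the series" means these compounds.

Measured so far in an assay on Huh-7 cells for agonist activity at Bile acid receptor (Homo sapiens), read by a luciferase reporter; a higher number here means that more compound is needed for the effect, a lower number that less compound is needed:
- compound 1, `CCC(CC)n1c(-c2ccc(OCc3c(-c4c(Cl)cccc4Cl)noc3C(C)C)cc2)nc2ccc(C(=O)O)cc21`, gives 0.8 nM
- compound 2, `CC(C)c1onc(-c2c(Cl)cccc2Cl)c1COc1ccc(-c2nc3ccc(C(=O)O)cc3n2Cc2ccc(F)cc2)cc1`, gives 3.31 nM
- compound 3, `CC(C)c1onc(-c2c(Cl)cccc2Cl)c1COc1ccc(-c2nc3ccc(C(=O)O)cc3n2C2CCCCCC2)cc1`, gives 14.8 nM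

All three compounds share one core and differ only in the group on an aromatic nitrogen of the fused five-membered ring. Compound 3, which carries a cycloheptyl there, stands at the highest number of the three: compound 2 lies closer, with a 4.5-fold higher number from compound 2 to compound 3 (0.65 log units; beyond the scatter), and compound 1 lies furthest, with a 19-fold higher number from compound 1 to compound 3 (1.27 log units; beyond the scatter). Between the two smaller groups the step is a 4.1-fold higher number from compound 1 to compound 2 (0.62 log units; beyond the scatter).

Compound 4, `CC(C)c1onc(-c2c(Cl)cccc2Cl)c1COc1ccc(-c2nc3ccc(C(=O)O)cc3n2C(C)C)cc1`, has not yet been measured. Its difference from compound 3 is isopropyl in place of cycloheptyl on an aromatic nitrogen. The bearing steps are those away from the branched pentan-3-yl of compound 1: the cycloheptyl cost a large step and the 4-fluorobenzyl a modest one. Isopropyl is a branched alkyl like pentan-3-yl, only with fewer carbons, so the expectation is that the number drops back toward that of compound 1, though whether the full distance is regained is unknown. The estimated step is a 4.9-fold lower number from compound 3 to compound 4 (0.69 log units; beyond the scatter), a lower number. For compound 4 the estimate in this assay is 3 nM, with a range from 0.8 nM to 12 nM.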

Compound 4, half-maximal effective concentration: 3.39 nM
Compound 4: the middle estimate sits 1.1-fold (0.05 log units) below what was measured; the range from low to high includes it.
By their numbers in this assay, from the lowest: compound 1; then compounds 2 and 4 (each within the scatter of the next); then compound 3.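

In this assay, the open-chain isopropyl in place of the cycloheptyl ring gives a 4.4-fold lower number from compound 3 to compound 4 (0.64 log units; beyond the scatter), so a ring on the aromatic nitrogen is not needed for a lower number. Isopropyl still does not reach pentan-3-yl, with a 4.2-fold higher number from compound 1 to compound 4 (0.63 log units; beyond the scatter): among the three alkyl groups, pentan-3-yl gives the lowest number, while both isopropyl, with fewer carbons, and cycloheptyl give higher ones, so the number does not move in one direction with the carbon count. The step from 4-fluorobenzyl to isopropyl is a 1.0-fold higher number from compound 2 to compound 4 (0.01 log units; within the scatter), which shows that two groups as different as these cannot be told apart at this position in this assay.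

Nothing shown explains why pentan-3-yl stands apart from isopropyl, and no measurement bears on the cause of any of these steps. Open too, from the compounds shown here alone, is where groups such as cyclopentyl, a straight propyl chain or an unsubstituted benzyl would fall, and whether any group on this nitrogen could give a lower number than pentan-3-yl.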